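Lengthening the sulfur chain on a bromophenyl dithioester

This account rests on a few compounds, and the source may have more. Where it says the series, first, only, none or still open, it means among the compounds named here.

Compound 2, `CCCCSC(=S)C1=C(Nc2ccc(Br)cc2)CC(C)(C)CC1=O`, was tested in a functional assay on PBMC cells (Homo sapiens) for inhibition, read by thymidine incorporation, with a stated time of 72 h; a higher number here means a weaker inhibitor, a lower number a stronger inhibitor. In this assay compound 2 reaches only a limit, > 50 ug/mL, not a measured number. Compound 1, `CCCCCCCCCCCSC(=S)C1=C(Nc2ccc(Cl)cc2Cl)CC(C)(C)CC1=O`, also stops at a limit in this assay, > 50 ug/mL. Both therefore sit at the limit of > 50 ug/mL in this assay, at which 2 of the 2 values shown sit. Compound 3, `CCCCCCCCCCCSC(=S)C1=C(Nc2ccc(Br)cc2)CC(C)(C)CC1=O`, is the untested neighbour of compound 2; the change is heptyl in place of hydrogen on a saturated chain carbon, four bonds along the chain from a sulfur. Given compound 1 at the limit of > 50 ug/mL in this assay, at which 2 of the 2 values shown sit, the expected step is a step that the limit leaves unreadable from compound 2 to compound 3, none beyond the scatter. Compound 3 is estimated at 60 ug/mL, within 30 ug/mL to 120 ug/mL.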

Compound 3, half-maximal inhibitory concentration: > 50 ug/mL
Compound 3: no number, only a limit (the forecaster's own chance of this, stated with the estimate: 80%); the middle value lies beyond the limit too.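

Compound 3 also stops at a limit, so no step can be read from it to compound 2 or compound 1: the limit of > 50 ug/mL in this assay, at which 3 of the 3 values shown sit.

The compounds shown leave open how strongly each one inhibits, and whether heptyl or 4-bromophenyl alters that at all.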